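Notes on a group swap from compound 3 to compound 4

The source may hold more compounds than are shown below. What is called first, only, known or untested is meant among the compounds shown, and "the series" means these compounds.

Measured so far in a functional assay on MCF7 cells (Homo sapiens) for cytotoxicity, read by MTT assay, with a stated time of 48 h (on this read-out lower numbers stand for stronger inhibition and higher numbers for weaker inhibition), for this series
- compound 1 `O=C1/C(=C\c2ccccc2)S/C(=N/c2ccccc2)N1Cc1ccncc1` gives 26400 nM
- compound 2 `CCOc1cc(/C=C2/S/C(=N/c3ccccc3)N(Cc3ccncc3)C2=O)ccc1O` gives 20100 nM
- compound 3 `COc1ccc(OC)c(/C=C2/S/C(=N/c3ccccc3)N(Cc3ccncc3)C2=O)c1` gives 37000 nM

Compound 3 (37000 nM) lies within the scatter of both other compounds, so the three values show no separation.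

Compound 4 `Cc1ccc(/C=C2/S/C(=N/c3ccccc3)N(Cc3ccncc3)C2=O)s1` is still unmeasured. It differs from compound 3 in one place, on a double-bonded chain carbon bound to a double-bonded ring carbon, where 5-methylthiophen-2-yl stands in place of 2,5-dimethoxyphenyl (5-methylthiophen-2-yl in place of 2,5-dimethoxyphenyl on a double-bonded chain carbon bound to a double-bonded ring carbon).

All three measured steps fall at that same place: a 1.3-fold lower number from compound 1 to compound 2 (0.12 log units; within the scatter) then a 1.4-fold higher number from compound 1 to compound 3 (0.15 log units; within the scatter) and finally a 1.8-fold higher number from compound 2 to compound 3 (0.27 log units; within the scatter) with none leaving the scatter. Going by the values given here, none of them involves 5-methylthiophen-2-yl, so the entering group has no direct precedent in these data, and the expectation rests only on how little the value moved across these three steps.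

A step beyond the scatter is therefore not expected, and the estimate is a 1.4-fold lower number from compound 3 to compound 4 (0.15 log units; within the scatter) in this assay on present evidence. The estimate for compound 4 is 26000 nM with an expected range from 12000 nM to 55000 nM until the measurement is available.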

Compound 4, half-maximal inhibitory concentration: 28700 nM
Compound 4: the middle estimate sits 1.1-fold (0.04 log units) below what was measured; measured number inside the range.
By their numbers in this assay, from the lowest: compounds 2, 1, 4 and 3 (each within the scatter of the next).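

Notes on the series after compound 4

In this assay, going by these compounds alone, the place on a double-bonded chain carbon bound to a double-bonded ring carbon now also accepts a five-membered aromatic ring with 1 hetero atom, where the earlier compounds all carried a six-membered aromatic ring of carbon only. With 5-methylthiophen-2-yl entering, each comparison stays within the scatter, whether it replaces 2,5-dimethoxyphenyl (a 1.3-fold lower number from compound 3 to compound 4 (0.11 log units; within the scatter)), 3-ethoxy-4-hydroxyphenyl (a 1.4-fold higher number from compound 2 to compound 4 (0.15 log units; within the scatter)) or phenyl (a 1.1-fold higher number from compound 1 to compound 4 (0.04 log units; within the scatter)), so neither the change of ring type nor the loss of the oxygen-bearing groups separates these compounds. No supporting evidence is available to explain this flat response.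

Still open, going by these compounds, is whether a carboxylic acid or an amine on the aromatic ring at this place, or a hexyl chain in place of that ring, would give a step beyond the scatter. On these data alone, every step shown sits at this one place, and the response to a change elsewhere on the shared core remains unknown.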